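From Methyl to Bromo on the Aromatic Ring

This account rests on a few compounds, and the source may have more. Where it says the series, first, only, none or still open, it means among the compounds named here.

In a functional assay on K562 cells (Homo sapiens) for inhibition, read by sulforhodamine B assay, with a stated time of 48 h (on this read-out higher numbers stand for weaker inhibition of growth and lower numbers for stronger inhibition of growth), compound 1 `S=C(N/N=C/c1cccs1)Nc1ccccc1` gives 16700 nM and compound 3 `C=CCNC(=S)N/N=C/c1cccs1` gives 6000 nM. Compound 2 `Cc1ccc(NC(=S)N/N=C/c2cccs2)cc1` gives < 900 nM, which is a limit of the assay and not a number. Compound 4 `S=C(N/N=C/c1cccs1)Nc1ccc(Br)cc1` follows from compound 2 through (bromo in place of methyl on an aromatic carbon), with bromo in place of methyl on an aromatic carbon. Going by the values given here, the only measured step at this place is an at least 18-fold lower number from compound 1 to compound 2 (1.26 log units; beyond the scatter), which is large but brings in methyl, not bromo. Compound 4 also carries a group there, so much of that gain is expected to remain, with a moderately higher number in this assay. The expected step is an at least 2.2-fold higher number from compound 2 to compound 4 (0.34 log units; beyond the scatter). For compound 4 the estimated value is 2000 nM, within an expected range of 500 nM to 9000 nM.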

Compound 4, concentration for 50% growth inhibition: > 100000 nM
Compound 4: no number, only a limit; the forecaster's own chance of this, stated with the estimate: 25%; middle value at least 50-fold (1.69 log units) from the limit.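

Putting bromo in place of methyl on the aromatic carbon gives an at least 110-fold higher number from compound 2 to compound 4 (2.04 log units; beyond the scatter), so at this place the identity of the group matters, not just the presence of one. Bromo does not keep the gain seen with methyl: replacing hydrogen with bromo gives an at least 5.9-fold higher number from compound 1 to compound 4 (0.77 log units; beyond the scatter). These steps are minimum sizes, and the reading for compound 4 is a limit and not a number: the limit of > 100000 nM in this assay, at which 1 of the 4 values shown sits.

Still open, on these data alone, is how an amine, a carboxylic acid or a longer chain would behave at this place. As far as these compounds go, the true size of the gap also stays open, since compound 2 too has only a limit.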